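This account rests on a few compounds, and the source may have more. Where it says the series, first, only, none or still open, it means among the compounds named here.

In a physicochemical assay for solubility, read by spectrophotometry, in phosphate buffer, with a stated time of 2 h, at pH 7.4 (on this read-out lower numbers stand for lower solubility and higher numbers for higher solubility), compound 1 `COc1ccc2[nH]c(C(=O)N3CC(=O)N(Cc4ccccc4)[C@@H](CN4CCC(C)CC4)C3)cc2c1` gives 93100 nM. Compound 3 `COc1ccc2[nH]c(C(=O)N3CC(=O)N(Cc4ccccc4)[C@@H](N4[C@H](C)CCC[C@@H]4C)C3)cc2c1` gives 100000 nM, and it sits together with compound 1, the step of a 1.1-fold higher number from compound 1 to compound 3 (0.03 log units; within the scatter) being within the scatter. For compound 2 `COc1ccc2[nH]c(C(=O)N3CC(=O)N(Cc4ccccc4)[C@@H](CN4CCCC4)C3)cc2c1` the result is only a limit of the assay, > 25000 nM. The steps a step that the limit leaves unreadable from compound 1 to compound 2 and a step that the limit leaves unreadable from compound 2 to compound 3 are therefore unreadable. Compound 4 `COc1ccc2[nH]c(C(=O)N3CC(=O)N(Cc4ccccc4)[C@@H](CN4CC5(CCC5)C4)C3)cc2c1` differs from compound 3 by a group of 8 heavy atoms (7 carbon, 1 nitrogen; one four-membered non-aromatic ring of carbon only, one four-membered non-aromatic ring with 1 hetero atom) in place of a group of 8 heavy atoms (7 carbon, 1 nitrogen; one six-membered non-aromatic ring with 1 hetero atom), on a saturated ring carbon. For the measured compounds named here, no measured step matches this change, and the one readable step stayed within the scatter, so no step beyond the scatter is expected in this assay. Compound 4 is therefore estimated at 90000 nM, with a range of 35000 nM to 200000 nM, which means an expected step of a 1.1-fold lower number from compound 3 to compound 4 (0.05 log units; within the scatter).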

Compound 4, solubility: 60700 nM
Beside the measured number, compound 4's estimate is 1.5-fold (0.17 log units) above it; the range from low to high includes it.
By their numbers in this assay, from the lowest: compounds 4, 1 and 3 (each within the scatter of the next).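

Replacing 2,6-dimethylpiperidin-1-yl on the saturated ring carbon with the group holding two four-membered non-aromatic rings gives a 1.6-fold lower number from compound 3 to compound 4 (0.22 log units; within the scatter) in this assay. The same group, set against the six-membered ring on the saturated chain carbon, gives a 1.5-fold lower number from compound 1 to compound 4 (0.19 log units; within the scatter), so neither comparison leaves the scatter. The step from compound 2 to compound 4 cannot be read, because compound 2 gives only a limit: the limit of > 25000 nM in this assay, at which 1 of the 4 values shown sits.

Still open, on these data alone, is whether an open-chain amine such as diethylamino, or a carboxylic acid, at this position would give a step beyond the scatter.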